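A Fluoro Swap on the Benzyl Ring

A few compounds are considered here, and "the series" means these few. Any claim that something is new, unique, unknown or untested is made for them only; others in the source may bear on it.

Compound 1 (`COc1cc(N(Cc2ccc(C)cc2)C(=O)CSc2nc3ccccc3s2)cc(OC)c1OC`) and compound 2 (`COc1cc(N(Cc2ccccc2)C(=O)CSc2nc3ccccc3s2)cc(OC)c1OC`) share one core and differ at a single spot on the benzyl ring. Among the measured compounds shown here, in a functional assay on MGC-803 cells (Homo sapiens) for antiproliferative activity, read by MTT assay, with a stated time of 48 h (on this read-out lower numbers stand for stronger inhibition and higher numbers for weaker inhibition), compound 1 gives 54200 nM and compound 2 gives 44300 nM, so compound 2 stands level with its only neighbour, within the usual scatter.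

Compound 3 (`COc1cc(N(Cc2ccc(F)cc2)C(=O)CSc2nc3ccccc3s2)cc(OC)c1OC`) comes from compound 2 by one change: fluoro in place of hydrogen on an aromatic carbon. This places fluoro in place of hydrogen on an aromatic carbon, at the same spot that carries the methyl in compound 1.

For the measured compounds named here, only one measured step bears on this spot: a 1.2-fold lower number from compound 1 to compound 2 (0.09 log units; within the scatter). It stayed within the scatter, but a single step is thin evidence, and it involves methyl, not fluoro. No shift beyond the scatter is therefore expected in this assay. The expected step is a 1.1-fold lower number from compound 2 to compound 3 (0.02 log units; within the scatter). Compound 3 is estimated at 42000 nM, with a range of 20000 nM to 85000 nM.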

Compound 3, half-maximal inhibitory concentration: > 80000 nM
Compound 3 gave a limit, no number; the forecaster's own chance of this, stated with the estimate: 10%; middle value at least 1.9-fold (0.27 log units) away from the limit.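

Compound 3 gives a limit in this assay, not a number: the limit of > 80000 nM in this assay, at which 1 of the 3 values shown sits.

Fluoro in place of hydrogen gives an at least 1.8-fold higher number from compound 2 to compound 3 (0.25 log units; that floor lies within the scatter), and fluoro in place of methyl gives an at least 1.4-fold higher number from compound 1 to compound 3 (0.16 log units; that floor lies within the scatter). Unlike the earlier step between compound 1 and compound 2, which has a measured size, these two steps set only a floor, so this position on the benzyl ring may respond more to fluoro than to methyl, but the true size of the change stays unknown and the floors alone do not settle it.

From the compounds shown here alone, it remains open how a chloro group, a methoxy group or an amine at this position would read in this assay. Going by these compounds, it is also open whether any group here could bring the number clearly lower than in compound 2.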